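The compounds below may be only part of what the source reports. "The series", "measured", "known", "first", "only" and "open" are said of these compounds alone.

In a functional assay on HeLa cells (Homo sapiens) for antiproliferative activity, read by CCK-8 assay, with a stated time of 72 h (a lower number here means a stronger inhibitor, a higher number a weaker inhibitor), compound 1 `O=C(Nc1cccc(-c2oc3cc(-c4ccc(F)cc4)ccc3c(=O)c2O)c1)c1ccc(F)cc1` gives 5350 nM, and compound 2 `O=C(Nc1cccc(-c2oc3cc(-c4ccc(F)cc4)ccc3c(=O)c2O)c1)c1ccc(Cl)cc1` gives 3670 nM. Within the data shown here, the only measured step, a 1.5-fold lower number from compound 1 to compound 2 (0.16 log units; within the scatter), exchanges one aromatic halogen for another on the amide-bearing ring. Compound 2 thus holds the lower of the two numbers, but it and compound 1 sit within the scatter of each other, so no order between them can be read.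

Compound 3 `Cc1ccccc1C(=O)Nc1cccc(-c2oc3cc(-c4ccc(F)cc4)ccc3c(=O)c2O)c1` differs from compound 2 by 2-methylphenyl in place of 4-chlorophenyl on a carbonyl carbon. Among the measured compounds shown here, no measured step covers an exchange of this kind: the halogen swap between compound 1 and compound 2 stayed within the scatter and says nothing about a methyl-bearing ring in place of a chlorine-bearing one. With nothing in the numbers pointing either way, the step of a 1.1-fold higher number from compound 2 to compound 3 (0.04 log units; within the scatter) is expected to remain inside the scatter in this assay. Compound 3 is therefore estimated at 4000 nM, with a range from 1500 nM to 11000 nM.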

Compound 3, half-maximal inhibitory concentration: 11900 nM
Compound 3: the middle estimate sits 3.0-fold (0.47 log units) below what was measured; the whole stated range lies below it.
By their numbers in this assay, from the lowest: compounds 2 and 1 (each within the scatter of the next); then compound 3.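

In this assay the group on the carbonyl carbon now separates compounds: 2-methylphenyl in place of 4-chlorophenyl gives a 3.2-fold higher number from compound 2 to compound 3 (0.51 log units; beyond the scatter) and 2-methylphenyl in place of 4-fluorophenyl gives a 2.2-fold higher number from compound 1 to compound 3 (0.35 log units; beyond the scatter) as modest steps beyond the scatter. The halogen exchange at this place gave no readable order, so this position is not indifferent to every aryl group, and compound 3 stands apart from both halogen-bearing compounds. Nothing at hand gives a reason for this difference.

Since 2-methylphenyl and 4-chlorophenyl differ both in the substituent and in the number in the name, the step cannot be divided between those two changes. On these data alone, how an unsubstituted phenyl, or a ring carrying an amine or a carboxylic acid, would read at this place stays open.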